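A few compounds are considered here, and "the series" means these few. Any claim that something is new, unique, unknown or untested is made for them only; others in the source may bear on it.

Working notes on the series.

Compound 1 `O=C(NCc1ccc(F)cc1)c1nc(NCCO)c2cccnc2c1O` and compound 2 `NCCCNc1c(C(=O)NCc2ccc(F)cc2)nc(Br)c2cccnc12` share a core and the amide to the fluorobenzyl group; they differ in the amine substituent and in the group facing it on the ring. In a functional assay on MDA-MB-435 cells (Homo sapiens) for cytotoxicity, read by MTT assay, with a stated time of 72 h (a lower number here means a stronger inhibitor, a higher number a weaker inhibitor), compound 1 returns only a limit, > 20000 nM, and not a number. For the measured compounds named here, compound 2 is the one member of the pair with a measured number: in this assay compound 2 gives 5000 nM. Nothing else is measured, so compound 2 stands alone among the numbers, the other value sitting at the assay limit (the limit of > 20000 nM in this assay, at which 1 of the 2 values shown sits).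

Compound 3 `O=C(NCc1ccc(F)cc1)c1nc(Br)c2cccnc2c1N1CCNCC1` has not yet been measured. It differs from compound 2 in one place: piperazin-1-yl in place of (3-aminopropyl)amino on an aromatic carbon. The bromo group and the amide are kept, so the change is confined to the amine.

Going by the values given here, with a single measured number and no measured step in the set, the direction of the change cannot be read from the data; the expected step from compound 2 to compound 3, no change at the digits printed from compound 2 to compound 3 (within the scatter), is taken as none beyond the usual scatter. In this assay compound 3 is estimated at 5000 nM, within a range of 1500 nM to 20000 nM.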

Compound 3, half-maximal inhibitory concentration: 8000 nM
Beside the measured number, compound 3's estimate is 1.6-fold (0.20 log units) below it, and the stated range covers the measured number.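

In this assay the series now shows its first step between two numbers, with a 1.6-fold higher number from compound 2 to compound 3 (0.20 log units; within the scatter) on exchange of the amine alone. On this aromatic carbon, para to a bromo group, the open (3-aminopropyl)amino chain and the piperazin-1-yl ring are not told apart by this read-out, although the entering group brings a six-membered non-aromatic ring where the leaving group has no ring. With the bromo group and the amide to the fluorobenzyl group kept, this position therefore takes a ring in place of a chain with no change beyond the scatter, a statement that holds for this one pair and reaches no further along the series.

On these data alone, whether a 4-methylpiperazin-1-yl or morpholin-4-yl ring, or a shorter chain such as (2-aminoethyl)amino, would move the number beyond the scatter at this position stays open, as does the part played by the bromo group, which stays fixed in this pair. No measurement shown here gives a cause for the size of this step, and none says what the amine contributes to the activity of the shared core.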